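The source may report more compounds than this note shows. Statements on the series, on what has been measured and on what is new or still open speak of the compounds shown alone.

Compound 1 `C[C@@H]1CN(c2cccc3c2C[C@H](CN(C)[C@H]2CCCc4cccnc42)NC3)C[C@H](C)N1` sits at a limit in a functional assay on CCRF-CEM cells for agonist activity at C-X-C chemokine receptor type 4 (Homo sapiens), read by calcium flux, with a stated time of 25 min; a lower number here means that less compound is needed, a higher number that more compound is needed for the effect: in this assay compound 1 gives > 30000 nM. Compound 2 `Cc1cnc(CN(C)C[C@H]2Cc3c(cccc3N3CCNCC3)CN2)c(C)c1` also returns a limit, compound 2 giving > 30000 nM in this assay. Compound 3 `Cc1cnc2c(c1)CCC[C@@H]2N(C)C[C@H]1Cc2c(cccc2N2CCNCC2)CN1` stands at a limit too, compound 3 giving > 30000 nM in this assay. So far, then, the limit of > 30000 nM in this assay, at which 3 of the 3 values shown sit, is the whole of the record, with no numbered value among the three. Compound 4 `CN(C[C@H]1Cc2c(cccc2N2CCN3CCC[C@@H]3C2)CN1)[C@H]1CCCc2cccnc21` has not yet been measured in this assay. It differs from compound 1 at one place: a group of 9 heavy atoms (7 carbon, 2 nitrogen; one five-membered non-aromatic ring with 1 hetero atom, one six-membered non-aromatic ring with 2 hetero atoms) in place of a group of 8 heavy atoms (6 carbon, 2 nitrogen; one six-membered non-aromatic ring with 2 hetero atoms), on an aromatic carbon. Going by the values given here, no measured step exists between these compounds, so no size of step is established; the expected step is a number no higher from compound 1 to compound 4 (the limit leaves the size open), not beyond the scatter. Compound 4 is estimated at 30000 nM in this assay, with a range from 3000 nM to 100000 nM, and most probably another limit.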

Compound 4, half-maximal effective concentration: > 30000 nM
Compound 4: only a limit was reported; the forecaster's own chance of this, stated with the estimate: 75%; the middle value sits exactly at the limit.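

The step from compound 1 to compound 4 cannot be read, as both values in this assay are limits. The compounds shown leave open whether any change to the group on the aromatic carbon alters the response, the record standing at: the limit of > 30000 nM in this assay, at which 4 of the 4 values shown sit.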